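Extending a Methyl Substituent Into a Hydroxylated Chain

The source may report more compounds than this note shows. Statements on the series, on what has been measured and on what is new or still open speak of the compounds shown alone.

Compound 3 `COc1ccc(C)c(N2CCC(COc3cccc(C(CC(=O)O)C4CC4)c3)CC2)c1` is one of three compounds with a measured number. In a functional assay on cells for agonist activity at Free fatty acid receptor 1 (Homo sapiens), read by FLIPR and calcium flux, with a stated time of 60 min (on this read-out lower numbers stand for an effect already at smaller amounts and higher numbers for an effect only at larger amounts of compound), compound 3 gives 270 nM, the second highest of the three numbers. Compound 1 `COc1ccc(F)c(-c2ccc(COc3cccc([C@@H](CC(=O)O)C4CC4)c3)nc2CC(C)(C)C)c1` gives 150 nM in this assay, and compound 2 `COc1ccc(CCCC(C)(C)C)c(-c2ccc(COc3cccc(C(CC(=O)O)C4CC4)c3)cc2)c1` gives 410 nM; both of these lie within the usual scatter of the number for compound 3, so no order among the three compounds can be read from these numbers. Compound 4 `COc1ccc(CCC(C)(C)O)c(N2CCC(COc3cccc(C(CC(=O)O)C4CC4)c3)CC2)c1` has not yet been measured. It differs from compound 3 by 2-hydroxy-2-methylpropyl in place of hydrogen on a saturated chain carbon bound to an aromatic carbon. Among the compounds with values here, no step between measured compounds matches this change, so nothing measured tells how far this kind of addition moves the number; what the measured compounds show is that their three numbers all sit within the scatter of one another. The change is therefore expected to amount to a 1.2-fold lower number from compound 3 to compound 4 (0.09 log units; within the scatter), with no clear direction beyond the scatter. Compound 4 is estimated to give 220 nM in this assay, with a range from 70 nM to 700 nM.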

Compound 4, half-maximal effective concentration: 970 nM
The estimate for compound 4 lay 4.4-fold (0.64 log units) below the measured number, outside the stated range (above it).
By their numbers in this assay, from the lowest: compounds 1, 3 and 2 (each within the scatter of the next, the first and the last beyond it); then compound 4.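

In this assay, within the data shown here, 2-hydroxy-2-methylpropyl in place of hydrogen on a saturated chain carbon bound to an aromatic carbon gives a 3.6-fold higher number from compound 3 to compound 4 (0.56 log units; beyond the scatter), the first step at this position. The three earlier numbers lay too close to show whether this position responds to a change at all, whereas this step shows that it does, and that extending methyl to 3-hydroxy-3-methylbutyl here goes with an effect only at larger amounts of compound. Nothing measured among the compounds shown accounts for this step.

The compounds shown leave open whether the rise follows the longer chain or its hydroxyl, which a plain 3-methylbutyl chain or one ending in an amine would help to separate. They also leave open whether the same change would move the number similarly on the core of compound 1 or compound 2.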